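Benzyl for cyclohexyl on the ring nitrogen of compound 1

The source may hold more compounds than are shown below. What is called first, only, known or untested is meant among the compounds shown, and "the series" means these compounds.

Compound 1 `Cc1cccc(-c2cn3ccnc3c(-c3ccc4ncn(C5CCCCC5)c4c3)n2)c1` gives the highest number of the three measured compounds in a physicochemical assay for lipophilicity, using the shake flask method, in phosphate buffer, measured as octanol-water partition, with a stated time of 85 min, at pH 7.4 (a higher number here means a more lipophilic compound, a lower number a more polar compound), at 1.87. Compound 2 `c1csc(-c2cn3ccnc3c(-c3ccc4ncn(C5CCCCC5)c4c3)n2)c1` gives 1.38 in this assay, and compound 3 `FC(F)(F)c1cccc(-c2cn3ccnc3c(-c3ccc4ncn(C5CCCCC5)c4c3)n2)c1` gives 1.72. The measured steps all change the group on the aromatic carbon: a number 0.49 log units lower from compound 1 to compound 2 (beyond the scatter), a number 0.15 log units lower from compound 1 to compound 3 (within the scatter), and a number 0.34 log units higher from compound 2 to compound 3 (beyond the scatter).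

Compound 4 `Cc1cccc(-c2cn3ccnc3c(-c3ccc4ncn(Cc5ccccc5)c4c3)n2)c1` differs from compound 1 at a different place: benzyl in place of cyclohexyl on an aromatic nitrogen. Among the compounds with values here, no measured step touches the ring nitrogen, so none of the three steps bears directly on this change, and the expectation rests on the change in the group alone, with the shared core otherwise unchanged.

On that basis the partition coefficient of compound 4 is expected to fall modestly, giving an estimated step of a number 0.37 log units lower from compound 1 to compound 4 (beyond the scatter). Compound 4 is therefore estimated at 1.5 in this assay, with a range from 1 to 2.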

Compound 4, partition coefficient: 2.16
Beside the measured number, compound 4's estimate is 0.66 log units below it; measured number outside the range, above it.
By their numbers in this assay, from the lowest: compound 2; then compounds 3, 1 and 4 (each within the scatter of the next, the first and the last beyond it).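

In this assay, benzyl in place of cyclohexyl on an aromatic nitrogen gives a number 0.29 log units higher from compound 1 to compound 4 (within the scatter), which keeps this exchange within the scatter. Within the data shown here, the earlier steps all changed the group on the aromatic carbon, two of them beyond the scatter, whereas compound 4 gives the only reading for a change at the ring nitrogen, and on this read-out the two six-membered rings, aromatic and non-aromatic, cannot be told apart. No measurement at hand accounts for this result.

Still open, going by these compounds, is whether a longer alkyl chain on the ring nitrogen, or a benzyl carrying an amine or a carboxylic acid, would give a step beyond the scatter. Also open, on these data alone, is whether the same exchange gives a similar step with thiophen-2-yl or 3-(trifluoromethyl)phenyl in place of 3-methylphenyl on the aromatic carbon.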